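A Side Chain Without Its Phenyl

A few compounds are considered here, and "the series" means these few. Any claim that something is new, unique, unknown or untested is made for them only; others in the source may bear on it.

Among the compounds with values here, in a functional assay on A549 cells (Homo sapiens) for antiproliferative activity, read by MTT assay, with a stated time of 72 h (a lower number here means a stronger inhibitor, a higher number a weaker inhibitor), compound 1 `COc1cc2c(Nc3ccc(C#N)cc3)ncnc2cc1OCCCN1CCCCC1` gives 23500 nM, while compound 2 `COc1cc2c(Nc3ccc(C#N)cc3)ncnc2cc1OCCCN1CCC(c2ccccc2)CC1` gives 9500 nM, the lower of the two numbers measured so far. Compound 3 `COc1cc2c(Nc3ccc(C#N)cc3)ncnc2cc1OCCCN1CCN(C)CC1` has not yet been measured. It keeps the core of compound 2 but differs at the end of the side chain: 4-methylpiperazin-1-yl in place of 4-phenylpiperidin-1-yl on a saturated chain carbon, three bonds along the chain from an oxygen on an aromatic ring. In words, this is 4-methylpiperazin-1-yl in place of 4-phenylpiperidin-1-yl on a saturated chain carbon, three bonds along the chain from an oxygen on an aromatic ring.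

Within the data shown here, only one measured step bears on this change: a 2.5-fold lower number from compound 1 to compound 2 (0.39 log units; beyond the scatter), with phenyl in place of hydrogen on a saturated ring carbon. Compound 3 has no phenyl, so that modest step is expected to be largely given back. Among the measured compounds shown here, no measured step shows what 4-methylpiperazin-1-yl itself does, which leaves the expectation loose. The estimate is therefore a 2.5-fold higher number from compound 2 to compound 3 (0.40 log units; beyond the scatter), a modest expected move to a higher number in this assay. Compound 3 is expected at about 24000 nM, with an estimated range of 10000 nM to 60000 nM.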

Compound 3, half-maximal inhibitory concentration: 48800 nM
Compound 3: middle estimate off by 2.0-fold (0.31 log units), on the low side; measured number inside the range.
By their numbers in this assay, from the lowest: compound 2; then compound 1; then compound 3.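

The new compound shows that the end of this side chain, on a saturated chain carbon, three bonds along the chain from an oxygen on an aromatic ring, responds to more than the phenyl alone. In this assay the full exchange gives a 5.1-fold higher number from compound 2 to compound 3 (0.71 log units; beyond the scatter), but losing the phenyl does not account for the whole result, as the comparison with the plain ring gives a 2.1-fold higher number from compound 1 to compound 3 (0.32 log units; beyond the scatter), a move in the same direction with no phenyl on either side. The three end groups therefore stand in the order 4-phenylpiperidin-1-yl, piperidin-1-yl, 4-methylpiperazin-1-yl, from the lowest number to the highest, though nothing available explains this order.

Compound 3 differs from compound 1 by both a second ring nitrogen and a methyl, so the compounds shown leave open which of the two goes with the higher number; an unsubstituted piperazin-1-yl end group would separate them. They also leave open whether a phenyl on a piperazine ring, as in 4-phenylpiperazin-1-yl, would lower the number as it does on the piperidine ring of compound 2.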